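Swapping 4-methoxyphenyl for 3-hydroxyphenyl on the pendant ring

This account rests on a few compounds, and the source may have more. Where it says the series, first, only, none or still open, it means among the compounds named here.

Measured so far in a functional assay on SGC-7901 cells (Homo sapiens) for antiproliferative activity, read by MTT assay, with a stated time of 72 h; on this read-out lower numbers stand for stronger inhibition and higher numbers for weaker inhibition:
compound 1, `COc1cc(-n2cnc3ccc(-c4ccc(C(F)(F)F)cc4)cc32)cc(OC)c1OC`: 890 nM
compound 2, `COc1ccc(-c2ccc3ncn(-c4cc(OC)c(OC)c(OC)c4)c3c2)cc1`: 82 nM
compound 3, `COc1cc(-n2cnc3ccc(-c4cccc(C)c4)cc32)cc(OC)c1OC`: 1240 nM

Compound 2 gives the lowest number of the three, and both gaps to it lie beyond the scatter: an 11-fold lower number from compound 1 to compound 2 (1.04 log units; beyond the scatter) and a 15-fold higher number from compound 2 to compound 3 (1.18 log units; beyond the scatter). Compound 1 and compound 3 sit close together, a 1.4-fold higher number from compound 1 to compound 3 (0.14 log units; within the scatter). The next compound, compound 4 `COc1cc(-n2cnc3ccc(-c4cccc(O)c4)cc32)cc(OC)c1OC`, differs from compound 2 in one place: 3-hydroxyphenyl in place of 4-methoxyphenyl on an aromatic carbon. Among the measured compounds shown here, two measured steps bear on this. The step from compound 1 to compound 2 shows how much a methoxy group on this pendant ring is worth, and the step from compound 2 to compound 3 shows that 3-methylphenyl in place of 4-methoxyphenyl costs a large amount. Compound 4 keeps one hydrogen-bond acceptor and adds one hydrogen-bond donor, but it gives up the 4-methoxyphenyl that the best number rests on. Compound 4 is therefore expected to lose ground in this assay, a 6.1-fold higher number from compound 2 to compound 4 (0.79 log units; beyond the scatter), landing around 500 nM, estimated between 150 nM and 1800 nM.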

Compound 4, half-maximal inhibitory concentration: 53 nM
For compound 4 the middle estimate is 9.4-fold (0.97 log units) above the measured one, outside the stated range (below it).
By their numbers in this assay, from the lowest: compounds 4 and 2 (each within the scatter of the next); then compounds 1 and 3 (each within the scatter of the next).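

The pendant ring does not need 4-methoxyphenyl to keep a low number in this assay: with 3-hydroxyphenyl in its place there is a 1.5-fold lower number from compound 2 to compound 4 (0.19 log units; within the scatter), so the two groups cannot be told apart here. The sharpest contrast comes from changing a single group on the ring, as hydroxy in place of the methyl of 3-methylphenyl gives a 23-fold lower number from compound 3 to compound 4 (1.37 log units; beyond the scatter), and 3-hydroxyphenyl in place of 4-(trifluoromethyl)phenyl gives a similarly large change, a 17-fold lower number from compound 1 to compound 4 (1.23 log units; beyond the scatter). Nothing available here accounts for these differences.

The compounds shown leave open whether the hydroxy group or its place on the ring matters more, a question that 4-hydroxyphenyl and 3-methoxyphenyl would help to separate. They also leave open whether 3-aminophenyl, with an amine at that place, would give a similarly low number.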